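This account rests on a few compounds, and the source may have more. Where it says the series, first, only, none or still open, it means among the compounds named here.

Of the compounds shown here, two sharing one core have been measured so far in a functional assay on the whole organism (trachea) for inhibition, with Cavia porcellus as the target; on this read-out lower numbers stand for an effect already at smaller amounts and higher numbers for an effect only at larger amounts of compound. Among the compounds with values here, compound 1 `COc1ccccc1OCC1SCCN1C(=O)COC(C)=O` gives 25 mg/kg and compound 2 `COc1ccccc1OCC1SCCN1C(=O)CC(C)=O` gives 26 mg/kg, so compound 2 stands level with the only other measured compound, and no order can be read between them. Compound 3 `CCOC(=O)C(C)(C)C(=O)N1CCSC1COc1ccccc1OC` differs from compound 2 in one place, on the carbonyl carbon whose other neighbour is the amide-type nitrogen in a ring, where 1-(ethoxycarbonyl)-1-methylethyl takes the place of 2-oxopropyl: 1-(ethoxycarbonyl)-1-methylethyl in place of 2-oxopropyl on a carbonyl carbon. Within the data shown here, only one measured step bears on this, the exchange of acetoxy for acetyl on a saturated chain carbon bound to a carbonyl carbon, which gave a 1.0-fold higher number from compound 1 to compound 2 (0.02 log units; within the scatter). That single step is thin evidence. Among the measured compounds shown here, the group entering compound 3 is larger than either group compared there, and no measured compound carries anything like it. No direction can be argued from these data, so the best guess stays near the present level, with a wide margin on both sides. The expected change is a 1.0-fold lower number from compound 2 to compound 3 (0.02 log units; within the scatter), which would be no step beyond the scatter. Compound 3 is estimated at 25 mg/kg, with an expected range of 8 mg/kg to 80 mg/kg.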

Compound 3, dose for half-maximal effect: 48 mg/kg
Beside the measured number, compound 3's estimate is 1.9-fold (0.28 log units) below it; measured number inside the range.
By their numbers in this assay, from the lowest: compounds 1, 2 and 3 (each within the scatter of the next).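

In this assay, 1-(ethoxycarbonyl)-1-methylethyl in place of 2-oxopropyl on the carbonyl carbon gives a 1.8-fold higher number from compound 2 to compound 3 (0.27 log units; within the scatter) and, in place of acetoxymethyl, gives a 1.9-fold higher number from compound 1 to compound 3 (0.28 log units; within the scatter) on the same read-out. This place on the carbonyl carbon therefore accepts a branched group carrying an ethyl ester with no step beyond the scatter, something the earlier exchange of acetoxy for acetyl could not show, as those two groups resemble each other far more closely than either resembles the new one. No measurement available here accounts for the numbers of compound 3.

Whether an amine or a carboxylic acid at this carbonyl carbon, or a longer chain than those shown, would stay within the scatter remains open. From the compounds shown here alone, all three compounds share one core, so it is also open whether the same exchange would behave alike on another core, and whether any group at this place can bring the number clearly lower than those seen so far.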